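The compounds below may be only part of what the source reports. "The series", "measured", "known", "first", "only" and "open" are said of these compounds alone.

Compounds measured so far:

Compound 1 `Cc1cccc(/C=N/Nc2ncc3c(n2)n(C2CCCC2)c(=O)c(=O)n3C)c1`: 53600 nM
Compound 2 `Cn1c(=O)c(=O)n(C2CCCC2)c2nc(N/N=C/c3ccc(S(C)(=O)=O)cc3)ncc21`: 26600 nM
Compound 3 `Cn1c(=O)c(=O)n(C2CCCC2)c2nc(N/N=C/c3cc(C(F)(F)F)c(O)c(C(F)(F)F)c3)ncc21`: 17700 nM

All three share one core and differ only in the aryl group attached to the carbon with a double bond to nitrogen. In a functional assay on PC-3 cells (Homo sapiens) for antiproliferative activity, read by MTT assay (a higher number here means a weaker inhibitor, a lower number a stronger inhibitor), compound 2 gives 26600 nM, which sits within the scatter of both compound 1 and compound 3, so no ranking among the three can be read from these numbers. Compound 4 `Cn1c(=O)c(=O)n(C2CCCC2)c2nc(N/N=C/c3cccc(Cl)c3Cl)ncc21` carries 2,3-dichlorophenyl in place of 4-(methylsulfonyl)phenyl on a carbon with a double bond to nitrogen. Going by the values given here, the one step that bears on this kind of aryl swap, a 2.0-fold lower number from compound 1 to compound 2 (0.30 log units; within the scatter), stayed within the scatter. The expectation for compound 4 is therefore no change beyond the scatter, a step of a 1.1-fold lower number from compound 2 to compound 4 (0.03 log units; within the scatter). Compound 4 is estimated at 25000 nM, ranging from 9000 nM to 70000 nM.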

Compound 4, half-maximal inhibitory concentration: 17200 nM
Beside the measured number, compound 4's estimate is 1.5-fold (0.16 log units) above it; measured number inside the range.
By their numbers in this assay, from the lowest: compounds 4, 3, 2 and 1 (each within the scatter of the next, the first and the last beyond it).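

In this assay, replacing the aryl group gives a 1.5-fold lower number from compound 2 to compound 4 (0.19 log units; within the scatter), so 2,3-dichlorophenyl and 4-(methylsulfonyl)phenyl cannot be told apart. Against 3-methylphenyl, however, the same group gives a 3.1-fold lower number from compound 1 to compound 4 (0.49 log units; beyond the scatter), the first step here to pass the scatter, which shows that the aryl group on this carbon can shift the number, if only modestly. Nothing measured here explains that shift. On these data alone, it remains open how an aryl group carrying an amine or a carboxylic acid would behave at this place. A longer alkyl chain in place of the aryl ring is equally unexplored.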